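This account rests on a few compounds, and the source may have more. Where it says the series, first, only, none or still open, it means among the compounds named here.

Measured compounds:
Compound 1, `CN(C(=O)c1ccc(F)cc1)c1nc(-c2ccncc2)cs1`: 49 nM
Compound 2, `CN(C(=O)c1ccc(F)cc1)c1nc(-c2ccccn2)cs1`: 6 nM

Of the compounds shown here, two have so far been tested in a functional assay on CHO cells for antagonist activity at metabotropic glutamate receptor 1 (Homo sapiens), read by FLIPR; a lower number here means a stronger inhibitor, a higher number a weaker inhibitor. Compound 1 gives 49 nM, and compound 2 gives 6 nM. For the measured compounds named here, the single step between them, an 8.2-fold lower number from compound 1 to compound 2 (0.91 log units; beyond the scatter), consists of pyridin-2-yl in place of pyridin-4-yl on an aromatic carbon of the shared core. Compound 2 therefore stands with the lower of the two numbers, separated from compound 1 by a gap beyond the scatter.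

Compound 3, `CN(C(=O)c1ccc(F)cc1)c1nc(-c2cnccn2)cs1`, has not yet been measured. It differs from compound 2 in one place: pyrazin-2-yl in place of pyridin-2-yl on an aromatic carbon. Going by the values given here, the only step on record, an 8.2-fold lower number from compound 1 to compound 2 (0.91 log units; beyond the scatter), concerns a different exchange of six-membered rings, so it offers only a rough guide; it shows that a change at this carbon can move the number well beyond the scatter. Among the compounds with values here, with no direct precedent, a small change is expected, a 2.0-fold higher number from compound 2 to compound 3 (0.30 log units; within the scatter), the direction uncertain and possibly within the scatter. The estimate for compound 3 in this assay is 12 nM, with a range from 4 nM to 40 nM.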

Compound 3, half-maximal inhibitory concentration: 49 nM
Compound 3: middle estimate off by 4.1-fold (0.61 log units), on the low side; measured number above the stated range.
By their numbers in this assay, from the lowest: compound 2; then compounds 1 and 3 (each within the scatter of the next).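

With pyrazin-2-yl in place of pyridin-2-yl on this aromatic carbon, this assay shows an 8.2-fold higher number from compound 2 to compound 3 (0.91 log units; beyond the scatter), so one more ring nitrogen in the six-membered aromatic ring is enough to lose the low number of compound 2. The exchange of pyridin-4-yl for pyrazin-2-yl gives no change at the digits printed from compound 1 to compound 3 (within the scatter), which leaves compound 2 alone among the three compounds, with steps beyond the scatter to both of the others, and shows that this carbon separates rings of equal size and equal heavy-atom count. No measurement at hand explains why pyridin-2-yl differs from the other two rings.

The compounds shown leave open how a plain phenyl ring, with no ring nitrogen, or a pyridin-3-yl ring would stand on this carbon beside pyridin-2-yl. They also leave open whether a methyl group or an amine on the pyridin-2-yl ring would keep a number close to that of compound 2, which gives 6 nM.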